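The compounds below may be only part of what the source reports. "The series", "measured", "known", "first", "only" and "open" are said of these compounds alone.

Among the compounds with values here, compound 3 `COc1cc(N(Cc2nc3ccccc3[nH]2)C(=O)c2ccc(F)cc2)cc(OC)c1OC` stands second highest of the three numbers so far in a functional assay on PC-3 cells (Homo sapiens) for inhibition, read by MTT assay, with a stated time of 48 h (a higher number here means a weaker inhibitor, a lower number a stronger inhibitor), where compound 3 gives 21900 nM. Its nearest neighbour is compound 1 `COc1cc(N(Cc2nc3ccccc3[nH]2)S(=O)(=O)c2ccccc2)cc(OC)c1OC`, which in this assay gives 25500 nM; the step of a 1.2-fold lower number from compound 1 to compound 3 (0.07 log units; within the scatter) lies within the scatter. Furthest from it is compound 2 `COc1cc(N(Cc2nc3ccccc3[nH]2)S(=O)(=O)c2ccc(Br)cc2)cc(OC)c1OC`, which gives 6890 nM; here a 3.2-fold higher number from compound 2 to compound 3 (0.50 log units; beyond the scatter) lies beyond the scatter.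

Compound 4 `COc1cc(N(Cc2nc3ccccc3[nH]2)C(=O)c2cccc(Cl)c2)cc(OC)c1OC` differs from compound 3 by 3-chlorophenyl in place of 4-fluorophenyl on a carbonyl carbon. Within the data shown here, the only measured step that touches a change on that outer ring is a 3.7-fold lower number from compound 1 to compound 2 (0.57 log units; beyond the scatter), a modest shift where the ring sits on a sulfonyl group. Whether a chloro group at a different place on a carbonyl-borne ring behaves alike is not known from these three compounds, so the expectation for compound 4 is a small step downward at most, a 1.7-fold lower number from compound 3 to compound 4 (0.23 log units; within the scatter), not clearly beyond the scatter. In this assay compound 4 is therefore estimated at 13000 nM, with a range from 5000 nM to 35000 nM.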

Compound 4, half-maximal inhibitory concentration: > 50000 nM
Compound 4 was reported as a limit (the forecaster's own chance of this, stated with the estimate: 5%); middle value at least 3.8-fold (0.58 log units) from the limit.
By their numbers in this assay, from the lowest: compound 2; then compounds 3 and 1 (each within the scatter of the next). At a limit, above all of these: compound 4.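

In this assay, compound 4 is reported only as a limit and not as a number: the limit of > 50000 nM in this assay, at which 1 of the 4 values shown sits. Within the data shown here, putting 3-chlorophenyl in place of 4-fluorophenyl on the carbonyl carbon gives an at least 2.2-fold higher number from compound 3 to compound 4 (0.35 log units; beyond the scatter), the first change on the carbonyl-borne ring and one that moves the number upward, whereas bromo on the sulfonyl-borne ring gave a 3.7-fold lower number from compound 1 to compound 2 (0.57 log units; beyond the scatter). The bromo compound is now clearly separated, with an at least 7.2-fold higher number from compound 2 to compound 4 (0.86 log units; beyond the scatter), while the phenylsulfonyl compound is not, with an at least 1.9-fold higher number from compound 1 to compound 4 (0.29 log units; that floor lies within the scatter).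

The step changes the halogen and its place on the ring together, so the shown compounds cannot say which of the two matters. Also open, as far as these compounds go, is how a methoxy group or an amine on that outer ring would read in this assay.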